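Changing the benzyl substituent in compound 3

This account rests on a few compounds, and the source may have more. Where it says the series, first, only, none or still open, it means among the compounds named here.

Compound 1 `Cc1cc(-c2ccccc2)n(/C(N)=N/S(=O)(=O)c2cc(C)c(Cl)cc2SCc2ccc(C(F)(F)F)cc2)n1` and compound 2 `Cc1cc(S(=O)(=O)/N=C(\N)n2nccc2-c2ccccc2)c(SCc2ccc(C(F)(F)F)cc2)cc1Cl` share one core. In an ADME assay on microsomes from liver (Homo sapiens) for metabolic stability, read by LC-MS, using NADPH, tested at 5 uM (a higher number here means that the compound lasts longer, a lower number that the compound disappears faster), compound 1 gives 0.241 h, and compound 2 gives 0.176 h. For the measured compounds named here, compound 2 is one of only two measured compounds, and its step from the other, a 1.4-fold lower number from compound 1 to compound 2 (0.14 log units; within the scatter), lies within the scatter, so the two stand together rather than apart. Compound 3 `Cc1cc(S(=O)(=O)/N=C(\N)n2nccc2-c2ccccc2)c(SCc2ccccc2Cl)cc1Cl` differs from compound 2 in a single place: 2-chlorophenyl in place of 4-(trifluoromethyl)phenyl on a saturated chain carbon bound to a sulfur. Going by the values given here, no measured step touches this position; the only known step alters a methyl on an aromatic carbon elsewhere and stays within the scatter. The data therefore give no reason to expect a move beyond the scatter in this assay, and the expected step of a 1.1-fold higher number from compound 2 to compound 3 (0.06 log units; within the scatter) is small. Compound 3 is estimated at 0.2 h, with a range from 0.08 h to 0.5 h.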

Compound 3, half-life: 0.226 h
Compound 3: the middle estimate sits 1.1-fold (0.05 log units) below what was measured; measured number inside the range.
By their numbers in this assay, from the lowest: compounds 2, 3 and 1 (each within the scatter of the next).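

For the compounds shown here, replacing 4-(trifluoromethyl)phenyl with 2-chlorophenyl on the saturated chain carbon bound to a sulfur gives the first reading at this position: in this assay, the swap produces a 1.3-fold higher number from compound 2 to compound 3 (0.11 log units; within the scatter). Although 10 heavy atoms leave and 7 enter, and the substituent on the ring changes in both identity and location, compound 2 and compound 3 cannot be told apart in this assay. This single pair therefore shows that these two groups are interchangeable here, but it does not establish a wider pattern, and nothing available bears on the reason for the result. As far as these compounds go, it remains open whether an unsubstituted benzyl group, a benzyl group carrying a methoxy group or a nitrile, or a longer chain ending in a phenyl ring would also stay within the scatter. Any of these might instead shift the half-life clearly.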